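A few compounds are considered here, and "the series" means these few. Any claim that something is new, unique, unknown or untested is made for them only; others in the source may bear on it.

Measured to date in a functional assay on CCRF-CEM cells (Homo sapiens) for cytotoxicity, read by sulforhodamine B assay, with a stated time of 48 h, tested at 10 uM; on this read-out lower numbers stand for a stronger effect and higher numbers for a weaker effect at the one concentration tested:
compound 1 `COc1cc(-c2cc(/C=C/C(=O)c3ccc(N)cc3)[nH]n2)cc(OC)c1OC` gives -22%
compound 2 `COc1ccc(C(=O)/C=C/c2cc(-c3cc(OC)c(OC)c(OC)c3)n[nH]2)cc1OC` gives -26%
compound 3 `COc1ccc(C(=O)/C=C/c2cc(-c3cc(OC)c(OC)c(OC)c3)n[nH]2)cc1` gives -19%

Compound 3 has the highest of the three numbers; the steps that reach it are a number 3 percentage points higher from compound 1 to compound 3 (within the scatter) and a number 7 percentage points higher from compound 2 to compound 3 (within the scatter), both within the scatter, so no ordering among the three is claimed. Compound 4 `COc1cc(-c2cc(/C=C/C(=O)c3ccc(F)c(F)c3)[nH]n2)cc(OC)c1OC` is not yet measured; it differs from compound 3 thus: 3,4-difluorophenyl in place of 4-methoxyphenyl on a carbonyl carbon. All three measured steps change the aryl group on the carbonyl carbon, namely a number 4 percentage points lower from compound 1 to compound 2 (within the scatter), a number 3 percentage points higher from compound 1 to compound 3 (within the scatter) and a number 7 percentage points higher from compound 2 to compound 3 (within the scatter), and none moves the read-out beyond the scatter. Among the compounds with values here, no measured step brings in fluorine, so their bearing is indirect. The expected step is therefore a number 1 percentage points lower from compound 3 to compound 4 (within the scatter), nothing beyond the scatter. Compound 4 is estimated at -20%, within a range from -35% to -5%.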

Compound 4, a percentage reported as activity, at one concentration (the size of the read-out at that concentration, not a potency): 7%
Estimate against measurement, compound 4: 27 percentage points below, and the stated range ends below it.
By their numbers in this assay, from the lowest: compounds 2, 1 and 3 (each within the scatter of the next); then compound 4.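

In this assay, the aryl group on the carbonyl carbon now moves the read-out beyond the scatter: 3,4-difluorophenyl replaces 4-methoxyphenyl (a number 26 percentage points higher from compound 3 to compound 4 (beyond the scatter)), 3,4-dimethoxyphenyl (a number 33 percentage points higher from compound 2 to compound 4 (beyond the scatter)) and 4-aminophenyl (a number 29 percentage points higher from compound 1 to compound 4 (beyond the scatter)). The earlier exchanges at this position stayed within the scatter, so this position is not indifferent to the group it carries, and the change to 3,4-difluorophenyl goes with a weaker effect. Nothing available explains this shift.

On these data alone, it remains open whether a single fluorine, two chlorines or an unsubstituted phenyl would behave like 3,4-difluorophenyl or like the three groups that keep the stronger effect.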